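The source may hold more compounds than are shown below. What is called first, only, known or untested is meant among the compounds shown, and "the series" means these compounds.

Measured in a functional assay on HT-29 cells (Homo sapiens) for inhibition, read by sulforhodamine B assay, with a stated time of 96 h; on this read-out lower numbers stand for stronger inhibition of growth and higher numbers for weaker inhibition of growth:
- compound 1 `CC[C@@H](Nc1nc(NCc2ccccn2)c2ncn(C(C)C)c2n1)C(C)O`: 42000 nM
- compound 2 `CC[C@H](Nc1nc(NCc2ccccn2)c2ncn(C(C)C)c2n1)C(C)(C)O`: > 50000 nM (a limit of the assay, not a number)

Compound 2 has no number of its own, only a limit: the limit of > 50000 nM in this assay, at which 1 of the 2 values shown sits.

Compound 3 `CC[C@H](Nc1nc(NCc2ccccn2)c2ncn(C(C)C)c2n1)C(O)C(C)(C)C` is still to be measured. It carries 1-hydroxy-2,2-dimethylpropyl in place of the 1-hydroxy-1-methylethyl of compound 2, on a saturated chain carbon bound to a nitrogen on an aromatic ring and a saturated chain carbon: 1-hydroxy-2,2-dimethylpropyl in place of 1-hydroxy-1-methylethyl on a saturated chain carbon bound to a nitrogen on an aromatic ring and a saturated chain carbon.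

For the measured compounds named here, one measured step bears on this, a change in the same substituent: an at least 1.1-fold higher number from compound 1 to compound 2 (0.07 log units; that floor lies within the scatter). From the compounds shown here alone, it gives a floor only, so its true size remains open. With compound 1 at 42000 nM, growth inhibition in this assay is weak on both measured compounds, and no step beyond the scatter is expected.

The expected step is an at least 1.2-fold lower number from compound 2 to compound 3 (0.09 log units; that floor lies within the scatter).

For compound 3 the estimated value is 40000 nM, with an expected range of 15000 nM to 50000 nM.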

Compound 3, concentration for 50% growth inhibition: 28000 nM
Beside the measured number, compound 3's estimate is 1.4-fold (0.15 log units) above it; low and high end bracket the measured number.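

In this assay, the place on a saturated chain carbon bound to a nitrogen on an aromatic ring and a saturated chain carbon now holds 1-hydroxy-2,2-dimethylpropyl, and the result is a number rather than a limit, with a step of a 1.5-fold lower number from compound 1 to compound 3 (0.18 log units; within the scatter) and so no separation between these two compounds. The other step reads an at least 1.7-fold lower number from compound 2 to compound 3 (0.25 log units; that floor lies within the scatter), which is a floor only, and even this floor does not separate the two compounds. Compound 2 holds a limit, not a number: the limit of > 50000 nM in this assay, at which 1 of the 3 values shown sits.

From the compounds shown here alone, the true size of the step involving compound 2 stays open. Also open is whether any group at this place can give a step beyond the scatter, since all the groups shown are hydroxy-bearing alkyl groups, with no amine, carboxylic acid or ring among them.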